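The compounds below may be only part of what the source reports. "The series", "measured", "known", "first", "only" and "open" are said of these compounds alone.

Measured in an ADME assay on the whole organism (plasma) for pharmacokinetics, with Rattus norvegicus as the target, with a stated time of 6 h, at a dose of 10 mg/kg by the oral route; on this read-out lower numbers stand for lower exposure and higher numbers for higher exposure at the dose given:
- compound 1 `CCc1nccc2sc(-c3c(C)nc(N[C@H](C)c4ccc(OC(F)(F)F)cc4)nc3N[C@@H]3C[C@H](CO)[C@@H](O)[C@H]3O)nc12`: 3510 ng.h/mL
- compound 2 `Cc1nc(N[C@H](C)c2ccc(OC(F)(F)F)cc2)nc(N[C@@H]2C[C@H](CO)[C@@H](O)[C@H]2O)c1-c1nc2c(CCC#N)nccc2s1`: 252 ng.h/mL

Of these two compounds, compound 1 has the higher number, at 3510 ng.h/mL. The unmeasured compound 3 `Cc1cc2sc(-c3c(C)nc(N[C@H](C)c4ccc(OC(F)(F)F)cc4)nc3N[C@@H]3C[C@H](CO)[C@@H](O)[C@H]3O)nc2c(C)n1` differs from it by one swap on an aromatic carbon: a group of 11 heavy atoms (8 carbon, 2 nitrogen, 1 sulfur; one five-membered aromatic ring with 2 hetero atoms, one six-membered aromatic ring with 1 hetero atom) in place of a group of 11 heavy atoms (8 carbon, 2 nitrogen, 1 sulfur; one five-membered aromatic ring with 2 hetero atoms, one six-membered aromatic ring with 1 hetero atom), on an aromatic carbon. The two have the same atoms, joined differently.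

Among the compounds with values here, only one measured step bears on this: a 14-fold lower number from compound 1 to compound 2 (1.14 log units; beyond the scatter). It is large and shows that a change within this same group can matter greatly in this assay. However, it adds a cyano group, and compound 3 gains none, so it offers only a loose guide. A much smaller step is therefore expected, more likely downward than upward. The expected step is a 1.8-fold lower number from compound 1 to compound 3 (0.24 log units; within the scatter). For compound 3 the estimate is 2000 ng.h/mL, with an expected range of 600 ng.h/mL to 6000 ng.h/mL.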

Compound 3, area under the concentration-time curve: 3390 ng.h/mL
Beside the measured number, compound 3's estimate is 1.7-fold (0.23 log units) below it; the range from low to high includes it.
By their numbers in this assay, from the lowest: compound 2; then compounds 3 and 1 (each within the scatter of the next).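

In this assay, joining the same atoms differently within the group on this aromatic carbon gives a 1.0-fold lower number from compound 1 to compound 3 (0.02 log units; within the scatter), so this rearrangement leaves the two numbers indistinguishable. The group therefore does not respond strongly to every change: its two aromatic rings and their atom counts stay the same here, whereas adding a cyano group gave a 14-fold lower number from compound 1 to compound 2 (1.14 log units; beyond the scatter). Nothing measured here explains why exposure differs so little between these two compounds.

These compounds leave open whether the result extends to other arrangements of this group, since only one rearrangement is shown. On these data alone, it also remains open how a primary amine, a carboxylic acid or a longer alkyl chain on this group would change the number in this assay.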